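Series notes: one thiophene exchange across two related cores

The compounds below may be only part of what the source reports. "The series", "measured", "known", "first", "only" and "open" are said of these compounds alone.

Measured so far:
compound 1 `N=C(N)N/N=C/c1c(-c2cccs2)nc2sccn12`: 12300 nM
compound 2 `Cc1cc(-c2nc3sccn3c2/C=N/NC(=N)N)c(C)s1`: 13800 nM
compound 3 `Cc1cc(-c2nc3n(c2/C=N/NC(=N)N)CCS3)c(C)s1`: 15500 nM

In a functional assay on cells (Cancer cell lines, Homo sapiens) for inhibition (on this read-out higher numbers stand for weaker inhibition of growth and lower numbers for stronger inhibition of growth), compound 2 gives 13800 nM and compound 1 gives 12300 nM. The two differ by thiophen-2-yl in place of 2,5-dimethylthiophen-3-yl on an aromatic carbon, and the step is a 1.1-fold lower number from compound 2 to compound 1 (0.05 log units; within the scatter), so the exchange leaves the read-out essentially unchanged on this core.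

Compound 3 carries the same 2,5-dimethylthiophen-3-yl group on a different core; the difference between the two cores is not broken down here. In this assay compound 3 gives 15500 nM, which lies within the scatter of both compound 2 and compound 1.

Compound 4 `N=C(N)N/N=C/c1c(-c2cccs2)nc2n1CCS2` has not yet been measured. It differs from compound 3 by thiophen-2-yl in place of 2,5-dimethylthiophen-3-yl on an aromatic carbon. This is the same kind of change as that from compound 2 to compound 1; around the place, the carbon in compound 3 is additionally two ring bonds from two ring atoms that each bear a fused ring, which is the only difference between the two surroundings.

Among the compounds with values here, the expectation for compound 4 rests on the single earlier example. Because a 1.1-fold lower number from compound 2 to compound 1 (0.05 log units; within the scatter) was within the scatter, the step from compound 3 to compound 4 is expected to be of similar size, a 1.1-fold lower number from compound 3 to compound 4 (0.04 log units; within the scatter). In this assay, within the data shown here, compound 4 is therefore estimated at 14000 nM, with a range from 7000 nM to 28000 nM, since only one precedent for the change exists and the cores are not identical.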

Compound 4, concentration for 50% growth inhibition: 19500 nM
Estimate against measurement, compound 4: 1.4-fold (0.14 log units) below; measured number inside the range.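

In this assay, thiophen-2-yl in place of 2,5-dimethylthiophen-3-yl gives a 1.3-fold higher number from compound 3 to compound 4 (0.10 log units; within the scatter), and setting this beside the step on the other core gives the following picture: the same change on two cores in this assay, a 1.1-fold lower number (0.05 log units; within the scatter) from compound 2 to compound 1 and a 1.3-fold higher number (0.10 log units; within the scatter) from compound 3 to compound 4, 1.4-fold (0.15 log units) apart, within the scatter of two such steps. The exchange therefore behaves alike on the two cores as far as this read-out can tell: neither step stands out from the scatter, and the two steps cannot be told apart. This does not show that the two groups are equivalent in general, since it rests on two matched pairs in one assay, an effect smaller than the scatter would go unseen, and steps this small say nothing about whether a large effect would carry from one core to the other.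

From the compounds shown here alone, all four compounds carry a thiophene on this aromatic carbon, so it remains open whether a different group there, such as a phenyl ring, a simple amine or a longer alkyl chain, would move the growth read-out beyond the scatter on either core. The group of 6 heavy atoms on the neighbouring ring atom is the same throughout, which leaves open how a carboxylic acid or an amide at that place would read.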